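The source may hold more compounds than are shown below. What is called first, only, known or untested is meant among the compounds shown, and "the series" means these compounds.

Measured so far in a functional assay on the whole organism (Hindlimb, strain albino) with Mus musculus as the target, in the maximal electroshock model, with a stated time of 0.5 h; a lower number here means that less compound is needed, a higher number that more compound is needed for the effect:
compound 1 `COc1ccc(/C=C/C(=O)Nc2nc3ccccc3s2)cc1` gives 435 umol/kg
compound 2 `COc1ccc(/C=C/C(=O)Nc2nc3ccc(C)cc3s2)cc1` gives 209 umol/kg
compound 3 `COc1ccc(C2CC(Nc3nc4ccccc4s3)=NN2C(C)=O)cc1O` gives 259 umol/kg

Compound 1 has the highest number of the three in this assay. Its gap to compound 3 is within the scatter, so the two cannot be ordered. Among the compounds with values here, the one step that is defined in the set runs a 2.1-fold lower number from compound 1 to compound 2 (0.32 log units; beyond the scatter), a modest change that lies beyond the scatter.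

Compound 4 `O=C(/C=C/c1ccccc1)Nc1nc2ccccc2s1` differs from compound 1 at the six-membered aromatic ring of carbon only:

hydrogen in place of methoxy on an aromatic carbon

No measured step in the set concerns this position or this group; the only shown step, methyl in place of hydrogen on an aromatic carbon of the other ring system, does not bear on it, and the difference from compound 1 to compound 3 involves several changes at once and cannot be read as a single step. There is therefore no basis for expecting a step beyond the scatter in this assay in either direction. The number for compound 4 is estimated at 500 umol/kg, with a range of 220 umol/kg to 1100 umol/kg. The expected change, a 1.1-fold higher number from compound 1 to compound 4 (0.06 log units; within the scatter), is within the scatter.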

Compound 4, dose for half-maximal effect: 646 umol/kg
The estimate for compound 4 lay 1.3-fold (0.11 log units) below the measured number; low and high end bracket the measured number.
By their numbers in this assay, from the lowest: compounds 2, 3, 1 and 4 (each within the scatter of the next, the first and the last beyond it).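

In this assay, hydrogen in place of methoxy on an aromatic carbon of the six-membered aromatic ring of carbon only, para to a large group, gives a 1.5-fold higher number from compound 1 to compound 4 (0.17 log units; within the scatter) and so stays within the scatter. Within the data shown here, this is the first reading at this position: the earlier step, a 2.1-fold lower number from compound 1 to compound 2 (0.32 log units; beyond the scatter), concerned methyl in place of hydrogen at another place, and it says nothing about the methoxy. Within this one pair, the methoxy cannot be told apart from hydrogen, and compound 4 still gives a measurable dose without it, while no data shown here offer an explanation for this result.

Going by these compounds, whether any other group at this position would give a step beyond the scatter remains open, for example an amine, a hydroxyl, a chlorine atom, a carboxylic acid, or a longer chain such as ethoxy in place of methoxy. Also open, on these data alone, is whether methyl in place of hydrogen on the other side of the molecule would give a similar step on the core of compound 4, which lacks the methoxy.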